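The source may hold more compounds than are shown below. What is called first, only, known or untested is meant among the compounds shown, and "the series" means these compounds.

Measured compounds in a functional assay on HL-60 cells (Homo sapiens) for antiproliferative activity, read by MTT assay; a lower number here means a stronger inhibitor, a higher number a weaker inhibitor:
- compound 1 `O[C@H]1CO[C@H](COCc2ccccc2)[C@@H](OCc2ccccc2)[C@@H]1OCc1ccccc1`, "not active" (no number reported)
- compound 2 `OCCC[C@@H]1O[C@H](COCc2ccccc2)[C@@H](OCc2ccccc2)[C@H](OCc2ccccc2)[C@H]1O`, 19300 nM
- compound 3 `C=CC[C@@H]1O[C@H](COCc2ccccc2)[C@@H](OCc2ccccc2)[C@H](OCc2ccccc2)[C@H]1O`, 15100 nM

Compound 1 has no single number in this assay: it is recorded as "not active" (no number reported), so its standing against compound 2 and compound 3 cannot be placed on a scale. Among the measured compounds shown here, compound 2 and compound 3 both give weak inhibition, and the one measured step between them, a 1.3-fold lower number from compound 2 to compound 3 (0.11 log units; within the scatter), lies within the scatter.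

Compound 4 `c1ccc(COC[C@H]2OCC[C@@H](OCc3ccccc3)[C@@H]2OCc2ccccc2)cc1` is the untested member. It differs from compound 1 in one place: hydrogen in place of hydroxy on a saturated ring carbon. For the measured compounds named here, the only measured step concerns a chain substituent on a saturated chain carbon bound to a saturated ring carbon, not a hydroxy on a saturated ring carbon, so it does not bear directly on this change; it shows only that a small alteration on this core left activity within the scatter. With compound 1 reported as "not active" (no number reported) and compounds 2 and 3 weak, compound 4 is expected to remain weak or inactive in this assay. The estimate for compound 4 is 40000 nM, within 10000 nM to 150000 nM, with a high chance that only a limit is reported.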

Compound 4, half-maximal inhibitory concentration: 39300 nM
Compound 4: middle estimate off by 1.0-fold (0.01 log units), on the high side; low and high end bracket the measured number.
By their numbers in this assay, from the lowest: compounds 3 and 2 (each within the scatter of the next); then compound 4.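

Among the compounds shown here, compound 1 has only the entry "not active" (no number reported) in this assay and compound 4 gives 39300 nM there, so no step between the two can be read. No supporting evidence bears on this result. The compounds shown leave open how hydrogen in place of hydroxy on that saturated ring carbon affects activity on the shared core.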